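The compounds below may be only part of what the source reports. "The series", "measured", "known", "first", "only" and "open" are said of these compounds alone.

In a functional assay on HepG2 cells (Homo sapiens) for antiproliferative activity, read by MTT assay, with a stated time of 48 h (a lower number here means a stronger inhibitor, a higher number a weaker inhibitor), compound 1 `CCn1c(C(=O)NCCN)ccc1C(CC)(CC)c1ccc(OCCC(O)(CC)CC)c(C)c1` gives 1590 nM. Compound 2 `C=CCN(C)C(=O)c1ccc(C(CC)(CC)c2ccc(OCCC(O)(CC)CC)c(C)c2)n1CC` reads > 50000 nM, which is a limit and not a number. Compound 3 `CCC(C)C(NC(=O)c1ccc(C(CC)(CC)c2ccc(OCCC(O)(CC)CC)c(C)c2)n1CC)C(=O)OC` reads > 50000 nM, again only a limit, and so it stands at the limit of > 50000 nM in this assay, at which 2 of the 3 values shown sit.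

Compound 4 `CCOC(=O)CN(C)C(=O)c1ccc(C(CC)(CC)c2ccc(OCCC(O)(CC)CC)c(C)c2)n1CC` has not yet been measured. Its change from compound 3 lies on a carbonyl carbon whose other neighbours are aromatic carbon, where ((ethoxycarbonyl)methyl)(methyl)amino enters: a group of 8 heavy atoms (5 carbon, 1 nitrogen, 2 oxygen; no ring) in place of a group of 10 heavy atoms (7 carbon, 1 nitrogen, 2 oxygen; no ring), on a carbonyl carbon.

Going by the values given here, two measured steps bear on this change, and both are large: an at least 31-fold higher number from compound 1 to compound 2 (1.49 log units; beyond the scatter) and an at least 31-fold higher number from compound 1 to compound 3 (1.49 log units; beyond the scatter). Each removes the (2-aminoethyl)amino group, which compound 4 also lacks. The remaining step, a step that the two limits leave unreadable from compound 2 to compound 3, cannot be read, so it gives no guide to size or direction. Compound 4 is therefore expected to stay with compound 2 and compound 3, with no step beyond the scatter. The expected step is a number no higher from compound 3 to compound 4 (the limit leaves the size open). For compound 4 the estimated value is 50000 nM, with an expected range from 20000 nM to 120000 nM.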

Compound 4, half-maximal inhibitory concentration: 25300 nM
Compound 4: middle estimate off by 2.0-fold (0.30 log units), on the high side, and the stated range covers the measured number.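

With ((ethoxycarbonyl)methyl)(methyl)amino on the carbonyl carbon, compound 4 gives a measured number in this assay, so among the compounds shown, losing the (2-aminoethyl)amino group does not always end at a limit of the assay. That group's replacement still carries a large cost in this case (with a 16-fold higher number from compound 1 to compound 4 (1.20 log units; beyond the scatter)). The separation from the two limit compounds is only a floor that stays within the scatter, with an at least 1.9-fold lower number from compound 3 to compound 4 (0.29 log units; that floor lies within the scatter) and an at least 1.9-fold lower number from compound 2 to compound 4 (0.29 log units; that floor lies within the scatter), and these steps are floors because compound 2 and compound 3 each stand at a limit and not a number: the limit of > 50000 nM in this assay, at which 2 of the 4 values shown sit.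

The step between compound 2 and compound 3 cannot be read. The compounds shown leave open how a carboxylic acid in place of the ethoxycarbonyl group, or an amine on a longer chain at this carbonyl carbon, would read.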